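From Acetoxy to Hydroxy on Compound 1

A few compounds are considered here, and "the series" means these few. Any claim that something is new, unique, unknown or untested is made for them only; others in the source may bear on it.

- compound 1 (`CC(=O)O[C@H]1[C@@H](COC(=O)c2ccccc2)C[C@]2(OC(=O)/C=C/c3ccccc3)C(=O)/C(C)=C/[C@@H]3[C@H](CC[C@@]4(C)O[C@@H]4[C@@H]12)C3(C)C`) gives 7.9 as its value
- compound 2 (`C=C1[C@@H](OC(=O)C(C)C)[C@@H](OC(C)=O)C(=O)C(C)(C)/C=C/[C@H](C)[C@H](OC(=O)c2ccccc2)[C@@]2(O)C[C@H](C)[C@H](OC(C)=O)[C@@H]2[C@H]1OC(C)=O`) gives 4 as its value

Among the compounds with values here, these two numbers are the only measurements so far. In a physicochemical assay for lipophilicity (a lower number here means a more polar compound, a higher number a more lipophilic compound), compound 1 stands higher of the two, at 7.9 with compound 2 at 4 under it, a gap well beyond the usual scatter.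

Compound 3 (`C/C1=C\[C@@H]2[C@H](CC[C@@]3(C)O[C@@H]3[C@H]3[C@@H](O)[C@@H](COC(=O)c4ccccc4)C[C@]3(OC(=O)/C=C/c3ccccc3)C1=O)C2(C)C`) has not been measured yet. It keeps the core of compound 1 and differs in one place only, with hydrogen in place of acetyl on an oxygen on a saturated carbon. Put more simply, an acetoxy becomes a hydroxy.

Within the data shown here, no measured pair shows this change. The two measured compounds differ in many places, and their gap gives no guide to its size, so the expectation rests on the structural change alone. A downward step is expected in this assay, modest beside the gap between the measured pair (the estimated step is a number 0.60 log units lower from compound 1 to compound 3 (beyond the scatter)). The expected value for compound 3 is 7.3 (expected range 6.7 to 7.7).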

Compound 3, partition coefficient: 7.2
Compound 3: middle estimate off by 0.10 log units, on the high side, within the range that was stated.
By their numbers in this assay, from the lowest: compound 2; then compound 3; then compound 1.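

Within the data shown here, compound 1 and compound 3 differ in one place only, so this is the first step in this assay that can be tied to a single change rather than to the many differences separating the two earlier compounds. Removing the acetyl from the oxygen on the saturated carbon gives a number 0.70 log units lower from compound 1 to compound 3 (beyond the scatter), a modest step for this position on the core of compound 1. The data show the size and direction of this step, but no measurement here explains it.

This single pair cannot show how other groups on the same oxygen would compare, such as a methyl ether, a longer ester chain like butanoyl, or an amine in place of the hydroxy. It also leaves open whether an acetoxy to hydroxy change at another position, or on a different core such as that of compound 2, would give a step of similar size in this assay.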